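Trading a Methoxy Group for Two Methyl Groups

The source may report more compounds than this note shows. Statements on the series, on what has been measured and on what is new or still open speak of the compounds shown alone.

Compound 2 `CCCc1nc(-c2ccccc2)c(CNCCCN2CCN(c3ccccc3OC)CC2)o1` was tested in an assay on HEK293 cells for inhibition of Voltage-dependent T-type calcium channel subunit alpha-1G (Homo sapiens), read by fluorescence, tested at 10 uM (a lower number here means less inhibition, a higher number more inhibition at the concentration tested (going by the name of the read-out)), where compound 2 gives 41%. Compound 1 `CCCc1nc(-c2ccccc2)c(CNCCN2CCN(c3ccccc3Cl)CC2)o1` shares the same core, and in this assay compound 1 gives 60.1%; compound 2 therefore holds the lower of the two numbers, and its gap to compound 1 lies beyond the usual scatter. Compound 3 `CCCc1nc(-c2ccccc2)c(CNCCCN2CCN(c3ccc(C)c(C)c3)CC2)o1` has not been measured yet. Its change from compound 2 is 3,4-dimethylphenyl in place of 2-methoxyphenyl on an amine nitrogen in a ring. For the measured compounds named here, the two measured compounds differ from each other in more than one part of the molecule, so no measured step shows how this single replacement on the ring amine behaves. Both measured numbers sit in the middle range, and the new group matches the old one in heavy-atom count on the same kind of aromatic ring, so for compound 3 the expected step of a number 4 percentage points higher from compound 2 to compound 3 (within the scatter) is small and may fall within the scatter. Compound 3 is expected to reach about 45%, between 25% and 65%.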

Compound 3, a percentage reported as inhibition, at one concentration (the size of the read-out at that concentration, not a potency): 54.6%
The estimate for compound 3 lay 9.6 percentage points below the measured number; measured number inside the range.
By their numbers in this assay, from the lowest: compound 2; then compounds 3 and 1 (each within the scatter of the next).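

In this assay, placing 3,4-dimethylphenyl instead of 2-methoxyphenyl on the amine nitrogen in the ring gives a number 13.6 percentage points higher from compound 2 to compound 3 (beyond the scatter). For the compounds shown here, this is the first single-place change, and it shows that the read-out responds to the aromatic group at this position even when the heavy-atom count stays the same. It also shows that this level of inhibition can be reached without the hydrogen-bond acceptor of the leaving group, although nothing available explains why the number rises.

The change alters both the kind of substituent and where it sits on the aromatic ring, so the two effects cannot be separated here. A 3,4-dimethoxyphenyl group on the same nitrogen would help to tell them apart.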